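The compounds below may be only part of what the source reports. "The series", "measured", "known", "first", "only" and "open" are said of these compounds alone.

Working notes on the series. The shared core carries a five-membered aromatic group at the same position in each compound. Compound 1 `COc1ncnc2c1c(-c1ccsc1)cn2[C@@H]1O[C@H](CO)[C@@H](O)[C@H]1O` gives 2570 nM in a functional assay on CCRF-CEM cells (Homo sapiens), read by MTT assay, with a stated time of 72 h; on this read-out higher numbers stand for weaker inhibition and lower numbers for stronger inhibition. Among the measured compounds shown here, compound 2 `O=c1[nH]cnc2c1c(-c1ccoc1)cn2[C@@H]1O[C@H](CO)[C@@H](O)[C@H]1O` gives 9030 nM in this assay, the highest of the two numbers so far; its nearest neighbour is compound 1, whose number is lower by a gap beyond the usual scatter. For the measured compounds named here, the two differ in more than one place, so no single step between measured compounds can be read from them, and nothing is yet known about how a change of the five-membered aromatic group alone moves the read-out.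

Compound 3 `O=c1[nH]cnc2c1c(-c1ccco1)cn2[C@@H]1O[C@H](CO)[C@@H](O)[C@H]1O` is the next member to be measured. It differs from compound 2 by furan-2-yl in place of furan-3-yl on an aromatic carbon; the furan-3-yl group leaves and a furan-2-yl group enters, the same atoms joined differently. Going by the values given here, with no measured step of this kind to lean on, the expectation from compound 2 to compound 3 in this assay is a step of no more than the scatter, in no set direction, given as a 1.1-fold lower number from compound 2 to compound 3 (0.05 log units; within the scatter). Compound 3 is estimated at 8000 nM in this assay, within a range from 2500 nM to 25000 nM.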

Compound 3, half-maximal inhibitory concentration: > 20000 nM
Compound 3: a limit, no number (the forecaster's own chance of this, stated with the estimate: 10%); middle value at least 2.5-fold (0.39 log units) from the limit.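

In this assay the series now has its first step that can be read at a single place: furan-2-yl in place of furan-3-yl on an aromatic carbon gives an at least 2.2-fold higher number from compound 2 to compound 3 (0.34 log units; beyond the scatter). With the same atoms joined differently, the read-out at this position therefore depends on how the furan ring is attached, and not only on which atoms the group contains. Compound 3 carries a limit of the assay and not a number, so the step gives only a lower bound on the change: the limit of > 20000 nM in this assay, at which 1 of the 3 values shown sits.

Among the compounds shown here, compound 1 differs from compound 2 and compound 3 in more than one place, so no step from it can be read, and whether the same change of attachment would move the read-out on the core of compound 1 remains unknown. Also open, as far as these compounds go, are the true size of the step and how an amine or a carboxylic acid on this aromatic carbon, in place of the five-membered aromatic group, would move the read-out.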